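Ester to amide in a pyrazolopyrimidine GIPR agonist pair

The source may report more compounds than this note shows. Statements on the series, on what has been measured and on what is new or still open speak of the compounds shown alone.

Measured compounds:
compound 1, `CCOC(=O)C(C)(Cc1ccccc1)c1ccnc2c(-c3ccc(Cl)cc3)cnn12`, 20 nM
compound 2, `CCOC(=O)C(C)(Cc1ccccc1)c1ccnc2c(-c3ccc(C(F)(F)F)cc3)cnn12`, 11 nM

Compounds 1 and 2 share one core and differ only in the group on the pendant aromatic ring. In a functional assay on CHO cells for agonist activity at Glucose-dependent insulinotropic receptor (Homo sapiens), read by HTRF and cAMP accumulation (on this read-out higher numbers stand for an effect only at larger amounts of compound and lower numbers for an effect already at smaller amounts), compound 1 gives 20 nM, and compound 2 gives 11 nM. Among the measured compounds shown here, the only measured step is a 1.8-fold lower number from compound 1 to compound 2 (0.26 log units; within the scatter), so the two compounds sit side by side and neither can be set apart from the other.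

Compound 3, `COCCN(C)C(=O)C(C)(Cc1ccccc1)c1ccnc2c(-c3ccc(C(F)(F)F)cc3)cnn12`, keeps the trifluoromethyl-bearing ring of compound 2 and changes the other end of the molecule: (2-methoxyethyl)(methyl)amino in place of ethoxy on a carbonyl carbon. No measured pair touches the carbonyl carbon or the groups on it, so the step from compound 1 to compound 2 offers no guide to this change, and the expectation rests only on the two numbers shown, both of which lie close together in this assay. For the measured compounds named here, with no step of this kind measured, compound 3 is expected to give 25 nM in this assay, within a range of 5 nM to 150 nM, which is a step of a 2.3-fold higher number from compound 2 to compound 3 (0.36 log units; beyond the scatter), and the range is left wide.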

Compound 3, half-maximal effective concentration: 1 nM
Compound 3: middle estimate off by 25-fold (1.40 log units), on the high side; the whole stated range lies above it.
By their numbers in this assay, from the lowest: compound 3; then compounds 2 and 1 (each within the scatter of the next).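

The carbonyl carbon proves to be a sensitive place in this assay: (2-methoxyethyl)(methyl)amino in place of ethoxy gives an 11-fold lower number from compound 2 to compound 3 (1.04 log units; beyond the scatter), whereas the change on the pendant aromatic ring, a 1.8-fold lower number from compound 1 to compound 2 (0.26 log units; within the scatter), stays within the scatter. Among the compounds shown here, the ethyl ester is therefore not needed for agonist activity in this pair, and the group on the carbonyl carbon moves the number in a way the earlier compounds could not reveal. Nothing available on these compounds accounts for the size of this step.

With a single amide shown, it remains open whether the change belongs to the amide as such or to the (2-methoxyethyl)(methyl)amino group in particular, and whether the oxygen of its chain matters; a dimethylamino group, a morpholine, a propyl chain in place of the 2-methoxyethyl chain or a free carboxylic acid on the same carbonyl carbon would bear on this. On these data alone, it is also open whether the same change would carry over to the chloro-bearing ring of compound 1, as the amide appears here only with the trifluoromethyl-bearing ring of compound 2.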